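A few compounds are considered here, and "the series" means these few. Any claim that something is new, unique, unknown or untested is made for them only; others in the source may bear on it.

Among the compounds with values here, only two compounds have been measured so far. In a functional assay on DU-145 cells (Homo sapiens) for inhibition, read by trypan blue exclusion, with a stated time of 96 h (on this read-out lower numbers stand for stronger inhibition of growth and higher numbers for weaker inhibition of growth), compound 1 `Cc1ccc(CS/C(=C/c2ccc(O)cc2)C(=O)c2ccc(Cl)cc2)cc1` gives 10000 nM. Compound 2 `COc1cc(OC)c(/C=C(\C(=O)c2ccc(Br)cc2)S(=O)(=O)c2ccc(Br)cc2)c(OC)c1` gives > 100000 nM in this assay, and this is a limit of the assay, not a number. So compound 2 stands at the limit of > 100000 nM in this assay, at which 1 of the 2 values shown sits, and its true value is unknown.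

Compound 3 `COc1cc(OC)c(/C=C(\C(=O)c2ccc(Br)cc2)S(=O)(=O)Cc2ccc(Cl)cc2)c(OC)c1` keeps the rest of compound 2 and changes one group: 4-chlorobenzyl in place of 4-bromophenyl on a sulfonyl sulfur. In words, 4-chlorobenzyl sits in place of 4-bromophenyl on a sulfonyl sulfur. Within the data shown here, no measured pair shows this change on its own, so any forecast is uncertain.

Among the measured compounds shown here, the only guide is compound 1, which also carries a benzyl group on sulfur and gives 10000 nM. It differs from the other compounds in several further places, so this is a weak hint. Even so, a clear move towards stronger inhibition of growth in this assay is expected, although compound 3 could also stay at the limit. The expected change is an at least 10-fold lower number from compound 2 to compound 3 (1.00 log units; beyond the scatter). The estimate for compound 3 is 10000 nM, with an expected range of 1000 nM to 100000 nM.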

Compound 3, concentration for 50% growth inhibition: 25000 nM
For compound 3 the middle estimate is 2.5-fold (0.40 log units) below the measured one; low and high end bracket the measured number.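

On a sulfonyl sulfur, this position clearly affects the read-out: putting 4-chlorobenzyl in place of 4-bromophenyl gives an at least 4.0-fold lower number from compound 2 to compound 3 (0.60 log units; beyond the scatter) in this assay. Within the data shown here, this is the first single-place comparison, and it shows that the group on the sulfonyl sulfur can by itself move a compound from the limit of the assay to a measurable number. The true size of the step remains unknown, and the printed size is only its lower bound, since the value for compound 2 is a limit and not a number: the limit of > 100000 nM in this assay, at which 1 of the 3 values shown sits.

The change replaces bromine with chlorine and phenyl with benzyl at the same time, so the compounds shown cannot tell which of these two differences accounts for the step. Going by these compounds, it also remains open how other groups on the sulfonyl sulfur would behave, such as an unsubstituted benzyl, 4-bromobenzyl, a longer chain ending in a phenyl ring, or a chain carrying an amine.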